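This account rests on a few compounds, and the source may have more. Where it says the series, first, only, none or still open, it means among the compounds named here.

Compound 1 `O=C(Nc1ccc(Sc2nc3ccccc3s2)cc1)c1cc(Br)cc(Br)c1O`: in an ADME assay on HEK293 cells (Homo sapiens) for cytotoxicity, read by resazurin assay, with a stated time of 48 h (on this read-out higher numbers stand for lower toxicity in this test and lower numbers for higher toxicity in this test), compound 1 gives 69000 nM.
Compound 2 `O=C(Nc1ccc(Sc2nc3ccccc3s2)cc1)c1cccc(Br)c1O`: in this assay compound 2 gives 33000 nM.

Compound 2 stands lowest of the two numbers shown, and its nearest neighbour is compound 1, separated from it by the step of a 2.1-fold lower number from compound 1 to compound 2 (0.32 log units; beyond the scatter).

Compound 3 `COc1c(Br)cccc1C(=O)Nc1ccc(Sc2nc3ccccc3s2)cc1` has not yet been measured. It differs from compound 2 in one place: methyl in place of hydrogen on an oxygen on an aromatic ring. Among the measured compounds shown here, none of the measured steps bears on a change at this oxygen; the only measured step, a 2.1-fold lower number from compound 1 to compound 2 (0.32 log units; beyond the scatter), concerns a bromo on an aromatic carbon and says nothing about what happens when hydroxy becomes methoxy. The direction of the coming step therefore cannot be read from the data, and the most defensible expectation is no step beyond the scatter, with a wide range to either side. Compound 3 is estimated at 35000 nM, within a range from 12000 nM to 100000 nM. This estimate amounts to an expected step of a 1.1-fold higher number from compound 2 to compound 3 (0.03 log units; within the scatter).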

Compound 3, half-maximal cytotoxic concentration: > 100000 nM
Compound 3: only a limit was reported (the forecaster's own chance of this, stated with the estimate: 15%); middle value at least 2.8-fold (0.45 log units) from the limit.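

In this assay, turning the hydroxy into a methoxy, with methyl in place of hydrogen on the oxygen, gives an at least 3.0-fold higher number from compound 2 to compound 3 (0.48 log units; beyond the scatter). This oxygen is therefore a place where one small change moves the read-out towards lower toxicity in this test. The value of compound 3 is a limit of the assay and not a number, so only a floor for this step is known: the limit of > 100000 nM in this assay, at which 1 of the 3 values shown sits. The other new step, an at least 1.4-fold higher number from compound 1 to compound 3 (0.16 log units; that floor lies within the scatter), spans more than one place and only its floor is known, so it cannot be read further.

From the compounds shown here alone, how far the number would rise without the limit stays open. So does whether an ethoxy, a longer chain on this oxygen, or an amine in place of the hydroxy would move the read-out the same way.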